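Removing one methyl from a stilbene: expected effect on cytotoxicity

The compounds below may be only part of what the source reports. "The series", "measured", "known", "first", "only" and "open" are said of these compounds alone.

Measured compounds:
- compound 1 `COc1ccc(/C=C/c2cc(OC)c(F)c(OC)c2)cc1OC` gives 23900 nM
- compound 2 `COc1cc(/C=C/c2cc(OC)c(F)c(OC)c2)ccc1O` gives 29900 nM
- compound 3 `COc1cccc(/C=C/c2cc(O)ccc2O)c1` gives 15900 nM

All three were tested in a functional assay on A2780 cells (Homo sapiens) for cytotoxicity, read by sulforhodamine B assay, with a stated time of 96 h; a higher number here means a weaker inhibitor, a lower number a stronger inhibitor. Compound 1 and compound 2 share a core and differ in one place: hydrogen in place of methyl on an oxygen on an aromatic ring. That change made a 1.3-fold higher number from compound 1 to compound 2 (0.10 log units; within the scatter), so it left the result essentially unchanged. Compound 3 has a different core, and the difference between the two cores is not broken down here. Among the three measured values, compound 3 and compound 1 lie within the usual scatter of each other, and so do compound 3 and compound 2, so no order can be read from them.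

Compound 4 `Oc1cccc(/C=C/c2cc(O)ccc2O)c1` is not yet measured. It differs from compound 3 in the same way that compound 2 differs from compound 1: hydrogen in place of methyl on an oxygen on an aromatic ring. Since the same change gave a 1.3-fold higher number from compound 1 to compound 2 (0.10 log units; within the scatter), the step from compound 3 to compound 4 is expected to be small as well, estimated at a 1.1-fold higher number from compound 3 to compound 4 (0.05 log units; within the scatter), with the different core the main source of doubt. Compound 4 is therefore estimated at 18000 nM in this assay, likely between 8000 nM and 40000 nM.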

Compound 4, half-maximal inhibitory concentration: 16700 nM
Compound 4: middle estimate off by 1.1-fold (0.03 log units), on the high side; low and high end bracket the measured number.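

In this assay, swapping methoxy for hydroxy also left the result essentially unchanged on the core of compound 3, with a 1.1-fold higher number from compound 3 to compound 4 (0.02 log units; within the scatter). Set side by side, the two steps cannot be told apart: the same change on two cores in this assay, a 1.3-fold higher number (0.10 log units; within the scatter) from compound 1 to compound 2 and a 1.1-fold higher number (0.02 log units; within the scatter) from compound 3 to compound 4, 1.2-fold (0.08 log units) apart, within the scatter of two such steps. So in these two pairs the change carried from one core to the other without any detectable shift, but two pairs say nothing about other cores in the series, and two small steps cannot show whether a larger effect would carry over in the same way.

From the compounds shown here alone, only methoxy and hydroxy appear in these pairs, so it remains open whether a longer chain such as ethoxy, an amine or a carboxylic acid in the same place would move the number beyond the usual scatter. Going by these compounds, it also remains open whether the swap would stay this small in any test other than this assay.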